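This account rests on a few compounds, and the source may have more. Where it says the series, first, only, none or still open, it means among the compounds named here.

Measured so far:
compound 1 `CC(C)(C)c1cccc2c1CCC2NC(=O)Nc1cccc2[nH]ncc12` — 14 nM
compound 2 `O=C(Nc1cccc2[nH]ncc12)NC1CCc2c(C3CC3)cccc21` — 5 nM
compound 3 `O=C(Nc1cccc2[nH]ncc12)NC1CCc2ncccc21` — 5820 nM

In an assay on isolated protein for inhibition of transient receptor potential cation channel subfamily V member 1 (Homo sapiens), read by calcium flux (a lower number here means a stronger inhibitor, a higher number a weaker inhibitor), compound 2 gives the lowest number of the three. Compound 1 sits nearest, a 2.8-fold lower number from compound 1 to compound 2 (0.45 log units; beyond the scatter). Compound 3, which carries no substituent on its bicyclic part and has a different ring there, gives a far higher number.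

Compound 4 `O=C(Nc1cccc2[nH]ncc12)NC1CCc2ccccc21` is compound 2 with hydrogen in place of cyclopropyl on an aromatic carbon. For the measured compounds named here, only the step from compound 1 to compound 2 bears on it, and that swap between two substituents was modest. Going by the values given here, removing the cyclopropyl altogether is a larger change with no single-place precedent here; compound 3, which also lacks it, hints that the number rises. Compound 4 is therefore expected to give 150 nM (range 25 nM to 900 nM), an expected step of a 30-fold higher number from compound 2 to compound 4 (1.48 log units; beyond the scatter).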

Compound 4, half-maximal inhibitory concentration: 151 nM
Estimate against measurement, compound 4: 1.0-fold (0.00 log units) below, and the stated range covers the measured number.
By their numbers in this assay, from the lowest: compound 2; then compound 1; then compound 4; then compound 3.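

In this assay this position, on an aromatic carbon of a six-membered aromatic ring, tolerates a swap of substituents far better than it tolerates bare hydrogen. Removing cyclopropyl gives a 30-fold higher number from compound 2 to compound 4 (1.48 log units; beyond the scatter) and removing tert-butyl gives an 11-fold higher number from compound 1 to compound 4 (1.03 log units; beyond the scatter) while exchanging the two groups gave only a 2.8-fold lower number from compound 1 to compound 2 (0.45 log units; beyond the scatter) so among these compounds the presence of a substituent matters more than which of the two it is. Nothing available explains why this is so. As far as these compounds go, whether methyl, methoxy or an amine at this position would keep the number low remains open.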